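The compounds below may be only part of what the source reports. "The series", "measured", "known", "first", "only" and "open" are said of these compounds alone.

Measured so far:
- Compound 1 `COc1ccc(C(N)=O)cc1/C=C/c1ccccc1` gives 2400 nM in a functional assay on HUVEC cells (Homo sapiens) for inhibition, with a stated time of 4 days; a lower number here means a stronger inhibitor, a higher number a weaker inhibitor
- Compound 2 `COc1ccc(C(N)=O)cc1/C=C/c1ccccc1OC(F)(F)F` gives 8900 nM in this assay

Compound 2 holds the higher of the two numbers, with compound 1 as its nearest neighbour. Compound 3 `COc1ccc(C(N)=O)cc1/C=C/c1ccccc1Cl` has chloro in place of trifluoromethoxy on an aromatic carbon, ortho to a large group (chloro in place of trifluoromethoxy on an aromatic carbon). Going by the values given here, one measured step bears on this change (a 3.7-fold higher number from compound 1 to compound 2 (0.57 log units; beyond the scatter)). It is modest and put trifluoromethoxy in place of hydrogen. Among the compounds with values here, no step for chloro has been measured. A small move back toward compound 1 is therefore expected in this assay, meaning a lower number (expected: a 2.2-fold lower number from compound 2 to compound 3 (0.35 log units; beyond the scatter)). For compound 3 the estimated value is 4000 nM (expected range 1500 nM to 10000 nM).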

Compound 3, half-maximal inhibitory concentration: 23000 nM
The estimate for compound 3 lay 5.8-fold (0.76 log units) below the measured number; measured number above the stated range.
By their numbers in this assay, from the lowest: compound 1; then compound 2; then compound 3.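

In this assay, chloro in place of hydrogen on this aromatic carbon gives a 9.6-fold higher number from compound 1 to compound 3 (0.98 log units; beyond the scatter), so a second group now raises the number relative to hydrogen. Size by heavy-atom count does not order the pair: chloro, with fewer heavy atoms than trifluoromethoxy, gives a 2.6-fold higher number from compound 2 to compound 3 (0.41 log units; beyond the scatter). No measurement at hand accounts for this order.

Going by these compounds, whether a methyl or an amine here would also give a higher number than hydrogen remains open. So does whether chloro has the same effect on other carbons of this ring.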